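Aryl swap on the ring nitrogen: compound 3 to compound 4

The source may hold more compounds than are shown below. What is called first, only, known or untested is meant among the compounds shown, and "the series" means these compounds.

Compound 3 `Cc1ccc(-n2nncc2CN2C(=O)C3(C(C#N)=C(N)Oc4c3c3nc5ccccc5nc3c3ccccc43)c3ccccc32)c(C)c1` is the reference point here. In a functional assay on HepG2 cells (Homo sapiens) for antiproliferative activity, read by MTT assay, with a stated time of 48 h (a higher number here means a weaker inhibitor, a lower number a stronger inhibitor), compound 3 gives only a limit, > 50000 nM. Compound 1 `COc1ccc(-n2nncc2CN2C(=O)C3(C(C#N)=C(N)Oc4c3c3nc5ccccc5nc3c3ccccc43)c3ccccc32)cc1` also gives only a limit, > 50000 nM. Compound 2 `N#CC1=C(N)Oc2c(c3nc4ccccc4nc3c3ccccc23)C12C(=O)N(Cc1cnnn1-c1ccc(N)cc1)c1ccccc12` likewise gives only a limit, > 50000 nM. As stated in the limit of > 50000 nM in this assay, at which 3 of the 3 values shown sit, every value shown sits at that limit, so where compound 3 stands relative to the other two cannot be read from the numbers.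

Compound 4 `Cc1ccc(Cl)cc1-n1nncc1CN1C(=O)C2(C(C#N)=C(N)Oc3c2c2nc4ccccc4nc2c2ccccc32)c2ccccc21` differs from compound 3 in one place: 5-chloro-2-methylphenyl in place of 2,4-dimethylphenyl on an aromatic nitrogen. The measured steps that bear on this change all concern the group on the same aromatic nitrogen of the five-membered aromatic ring with 3 nitrogen: a step that the two limits leave unreadable from compound 1 to compound 3, a step that the two limits leave unreadable from compound 2 to compound 3 and, for the remaining pair, a step that the two limits leave unreadable from compound 1 to compound 2. None of them has a readable size, so neither a direction nor a magnitude can be drawn from them. Among the measured compounds shown here, what can be said is only that no exchange of the group on that nitrogen has yet brought a compound inside the measurable range of this assay.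

Against this background the step from compound 3 to compound 4 is expected to be a step that the limit leaves unreadable from compound 3 to compound 4, with no readable change in either direction. Compound 4 is therefore expected to give about 60000 nM (range 20000 nM to 200000 nM), most likely again reported only as a limit.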

Compound 4, half-maximal inhibitory concentration: > 50000 nM
Compound 4: no number, only a limit; the forecaster's own chance of this, stated with the estimate: 85%; the middle value does not contradict the limit.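

In this assay, no step can be read between compound 4 and compound 1, compound 2 or compound 3, and none can be read among those three: the limit of > 50000 nM in this assay, at which 4 of the 4 values shown sit.

The compounds shown leave open how these four rank against one another and whether any aryl group on that aromatic nitrogen gives the shared core a measurable value.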